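Isomeric ring swap at the amide nitrogen

The source may hold more compounds than are shown below. What is called first, only, known or untested is meant among the compounds shown, and "the series" means these compounds.

Three compounds have been measured in an assay on HEK293 cells for agonist activity at transient receptor potential cation channel subfamily M member 8 (Homo sapiens), read by fluorescence and calcium flux, with a stated time of 15 min; on this read-out higher numbers stand for an effect only at larger amounts of compound and lower numbers for an effect already at smaller amounts:

Compound 1 `Cc1ccc(OCC(=O)N(Cc2cccs2)c2ccnn2C)cc1`: 422 nM
Compound 2 `Cc1ccc(OCC(=O)N(Cc2cccs2)c2c(C)n[nH]c2C)cc1`: 0.3 nM
Compound 3 `Cc1ccc(OCC(=O)N(Cc2cccs2)c2ccon2)cc1`: 2 nM

Compound 3 gives the second highest of the three numbers. Its nearest neighbour is compound 2, and the step is a 6.7-fold higher number from compound 2 to compound 3 (0.82 log units; beyond the scatter). Compound 1 lies furthest away, with a step of a 210-fold lower number from compound 1 to compound 3 (2.32 log units; beyond the scatter). The third measured step, a 1400-fold lower number from compound 1 to compound 2 (3.15 log units; beyond the scatter), is the largest of all. Every one of these steps is a change of the heteroaryl group on the amide-type nitrogen, and each of them lies beyond the scatter.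

Compound 4 `Cc1ccc(OCC(=O)N(Cc2cccs2)c2ncco2)cc1` has not yet been measured. It differs from compound 3 in one place: 1,3-oxazol-2-yl in place of 1,2-oxazol-3-yl on an amide-type nitrogen. The two compounds share their atoms and differ only in how they are joined within that ring.

The measured steps show that this position reacts strongly to the identity of the heteroaryl group, but none of them compares two rings as alike as these, so the direction is open. A step beyond the scatter is possible in either direction; the expected step is a 3.0-fold higher number from compound 3 to compound 4 (0.48 log units; beyond the scatter), a modest rise in the number. For compound 4 the estimate in this assay is 6 nM, with a range from 1.5 nM to 30 nM.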

Compound 4, half-maximal effective concentration in the transient receptor potential cation channel subfamily M member 8 assay: 0.3 nM
Beside the measured number, compound 4's estimate is 20-fold (1.30 log units) above it, outside the stated range (below it).
By their numbers in the transient receptor potential cation channel subfamily M member 8 assay, from the lowest: compounds 2 and 4 (each within the scatter of the next); then compound 3; then compound 1.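

Putting 1,3-oxazol-2-yl in place of 1,2-oxazol-3-yl gives, in the transient receptor potential cation channel subfamily M member 8 assay, a 6.7-fold lower number from compound 3 to compound 4 (0.82 log units; beyond the scatter), so this position on the amide-type nitrogen tells apart two rings that have the same atoms, joined differently. Also in the transient receptor potential cation channel subfamily M member 8 assay, the comparison with the 3,5-dimethyl-1H-pyrazol-4-yl group shows no change at the digits printed from compound 2 to compound 4 (within the scatter), while the comparison with the 1-methyl-1H-pyrazol-5-yl group shows a 1400-fold lower number from compound 1 to compound 4 (3.15 log units; beyond the scatter), so a ring without any methyl group matches the dimethyl pyrazole in this read-out. In a physicochemical assay, with a stated time of 24 h, at 100 degrees C, at pH 7.1 (on this read-out higher numbers stand for a more stable compound and lower numbers for a less stable compound), compound 3 has 0.5% remaining and compound 4 has 0.1% remaining, two values within the scatter of each other, so the swap that separates the two compounds in the transient receptor potential cation channel subfamily M member 8 assay leaves no readable difference here.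

The data shown contain no measurement that accounts for the gap between the two oxazole rings. On these data alone, it remains open whether the low number of compound 4 would hold with a 1,3-thiazol-2-yl group in the same place, or with a methyl group added to the 1,3-oxazol-2-yl ring.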